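This account rests on a few compounds, and the source may have more. Where it says the series, first, only, none or still open, it means among the compounds named here.

Compound 1, `O=C(Nc1cccc(-n2cc(-c3ccncc3)c(-c3cc(O)cc(Cl)c3)n2)c1)Nc1ccc(Cl)c(Cl)c1`, and compound 2, `COc1cc(Cl)cc(-c2nn(-c3cccc(NC(=O)Nc4ccc(Cl)c(Cl)c4)c3)cc2-c2ccncc2)c1`, share one core; compound 3, `O=C(Nc1cccc(-n2cc(-c3ccncc3)c(-c3cc(O)cc(Cl)c3)n2)c1)c1cc(C(F)(F)F)cc(C(F)(F)F)c1`, and compound 4, `COc1cc(Cl)cc(-c2nn(-c3cccc(NC(=O)c4cc(C(F)(F)F)cc(C(F)(F)F)c4)c3)cc2-c2ccncc2)c1`, share another, and the difference between the two cores is not broken down here. In a functional assay on NCI-H23 cells (Homo sapiens) for inhibition, read by sulforhodamine B assay, with a stated time of 48 h, tested at 10 uM (on this read-out lower numbers stand for a stronger effect and higher numbers for a weaker effect at the one concentration tested), compound 1 gives -20.5%, while compound 2 gives 5.72%. The change between them, (methyl in place of hydrogen on an oxygen on an aromatic ring), gave a step of a number 26.2 percentage points higher from compound 1 to compound 2 (beyond the scatter), a weakening. Compound 3 gives 42.7% in this assay, the weakest effect of the three measured compounds. Compound 4 carries the same change, (methyl in place of hydrogen on an oxygen on an aromatic ring), at the same place. For the measured compounds named here, with only this one earlier pair to rest on, the step is expected to be a number 23.3 percentage points higher from compound 3 to compound 4 (beyond the scatter), matching the earlier pair whose step was a number 26.2 percentage points higher from compound 1 to compound 2 (beyond the scatter). Compound 4 is therefore estimated at 66%, expected to fall between 46% and 86%.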

Compound 4, a percentage reported as activity, at one concentration (the size of the read-out at that concentration, not a potency): 72.1%
Compound 4: the middle estimate sits 6.1 percentage points below what was measured; measured number inside the range.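

In this assay, turning hydroxy into methoxy on the 3-chloro-5-hydroxyphenyl group gave a step of a number 29.4 percentage points higher from compound 3 to compound 4 (beyond the scatter), again a weakening of the effect. For the compounds shown here, the same change therefore moved the read-out in the same direction and by a similar amount on both cores: the same change on two cores in this assay, a number 26.2 percentage points higher (beyond the scatter) from compound 1 to compound 2 and a number 29.4 percentage points higher (beyond the scatter) from compound 3 to compound 4, 3.2 percentage points apart, within the scatter of two such steps This is only two pairs in one assay at one concentration, so it supports carrying the change between these two cores but shows neither why the effect weakens nor that the step would hold on any other core.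

The compounds shown leave open whether a longer chain on that oxygen, such as ethyl, would weaken the effect in the same way. They also leave open what an amine in place of the hydroxy would do.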